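A few compounds are considered here, and "the series" means these few. Any claim that something is new, unique, unknown or untested is made for them only; others in the source may bear on it.

Of the compounds shown here, three from one series have been measured in a functional assay (Pituitary gland cell) with Rattus norvegicus as the target; a lower number here means that less compound is needed, a higher number that more compound is needed for the effect. Compound 1 `CC(C)(N)CC(=O)N[C@@H]1CCc2ccccc2N(Cc2ccc(-c3ccccc3C(=O)O)cc2)C1=O` gives 3 uM. Compound 2 `Cn1nnnc1-c1ccccc1-c1ccc(CN2C(=O)[C@H](NC(=O)CC(C)(C)N)CCc3ccccc32)cc1` gives 0.5 uM, and compound 3 `CC(C)(N)CC(=O)N[C@@H]1CCc2ccccc2N(Cc2ccc(-c3ccccc3-c3nnnn3Cc3ccccc3)cc2)C1=O` gives 0.7 uM. Compound 2 has the lowest number of the three: compound 3 sits within the usual scatter of it, while compound 1 lies beyond the scatter, the step being a 6.0-fold lower number from compound 1 to compound 2 (0.78 log units; beyond the scatter). The related change to compound 3, a 4.3-fold lower number from compound 1 to compound 3 (0.63 log units; beyond the scatter), points the same way, and the further change a 1.4-fold higher number from compound 2 to compound 3 (0.15 log units; within the scatter) stays within the scatter.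

Compound 4 `CC(C)(N)CC(=O)N[C@@H]1CCc2ccccc2N(Cc2ccc(-c3ccccc3C(N)=O)cc2)C1=O` has not yet been measured. It differs from compound 2 in one place: carbamoyl in place of 1-methyl-1H-tetrazol-5-yl on an aromatic carbon. Going by the values given here, no measured step matches this change exactly. The closest guide is the step from compound 1 to compound 2, where the 1-methyl-1H-tetrazol-5-yl group arrived in place of carboxy and the number fell modestly. Compound 4 gives that tetrazole up again, so the number is expected to move back upward, though compound 1 carries carboxy rather than carbamoyl, so the size is uncertain. The step from compound 2 is estimated at a 3.6-fold higher number from compound 2 to compound 4 (0.56 log units; beyond the scatter). Compound 4 is therefore expected to give about 1.8 uM in this assay, within a range from 0.6 uM to 6 uM.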

Compound 4, concentration for half-maximal effect: 0.08 uM
Beside the measured number, compound 4's estimate is 23-fold (1.35 log units) above it, outside the stated range (below it).
By their numbers in this assay, from the lowest: compound 4; then compounds 2 and 3 (each within the scatter of the next); then compound 1.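

The earlier compounds shown here showed only that a tetrazole at this position, on an aromatic carbon ortho to a large group, gives a lower number than carboxy in this assay. Compound 4 shows that a tetrazole ring is not needed for a low number, since the smaller carbamoyl group gives a 6.3-fold lower number from compound 2 to compound 4 (0.80 log units; beyond the scatter) and also an 8.8-fold lower number from compound 3 to compound 4 (0.94 log units; beyond the scatter) in the same series. Going by these compounds alone, the sharpest contrast is with carboxy: exchanging hydroxy for amino on the same carbonyl carbon gives a 38-fold lower number from compound 1 to compound 4 (1.57 log units; beyond the scatter) and is the only large step here, so this position clearly separates two groups that look closely alike on paper, although no information at hand explains why carbamoyl stands out.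

The compounds shown leave open whether the amide hydrogens matter, which a methylcarbamoyl or dimethylcarbamoyl group at the same position would help to test. They also leave open whether the carbonyl alone is enough, and a nitrile or an acetyl group would bear on that, while a primary sulfonamide would show how far the result extends beyond carbonyl groups.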